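Trimming the oxime chain of compound 3

This account rests on a few compounds, and the source may have more. Where it says the series, first, only, none or still open, it means among the compounds named here.

Of the compounds shown here, three sharing one core have been measured in a functional assay on A-375 cells (Homo sapiens) for antiproliferative activity; on this read-out higher numbers stand for weaker inhibition and lower numbers for stronger inhibition. Compound 1 `CO/N=C/c1c(N)ncnc1Oc1ccc2cccnc2c1` gives 886 nM and compound 2 `CO/N=C/c1c(N)ncnc1Oc1ccc2[nH]ccc2c1` gives 783 nM. Compound 3 `COCCCO/N=C/c1c(N)ncnc1Oc1ccc2[nH]c(C)cc2c1F` gives 300 nM, the lowest of the three; its gaps to compound 2 and to compound 1 both lie beyond the scatter, so compound 3 is the most potent of this set. Compound 4 `Cc1cc2c(F)c(Oc3ncnc(N)c3/C=N/O)ccc2[nH]1` differs from compound 3 in one place: hydrogen in place of 3-methoxypropyl on an oxygen. For the measured compounds named here, no measured pair shows this change, so its effect cannot be read from the data. A modest weakening is expected for compound 4, with the step of a 1.8-fold higher number from compound 3 to compound 4 (0.26 log units; within the scatter) sitting around the edge of the scatter. Compound 4 is estimated at 550 nM, within 180 nM to 1700 nM.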

Compound 4, half-maximal inhibitory concentration: 492 nM
Compound 4: the middle estimate sits 1.1-fold (0.05 log units) above what was measured; the measured number falls inside the stated range.
By their numbers in this assay, from the lowest: compounds 3, 4, 2 and 1 (each within the scatter of the next, the first and the last beyond it).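

In this assay, for the compounds shown here, hydrogen in place of 3-methoxypropyl on an oxygen gives a 1.6-fold higher number from compound 3 to compound 4 (0.21 log units; within the scatter) and so offers the first reading of this position: the whole chain can be exchanged for hydrogen without a difference that stands clear of the scatter. This single pair shows no dependence on the chain at this oxygen. Nothing measured here accounts for this result. The compounds shown leave open how a short methyl or ethyl group, a longer chain, or a chain ending in an amine or a carboxylic acid would read on this oxygen.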